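The compounds below may be only part of what the source reports. "The series", "measured", "known", "first", "only" and "open" are said of these compounds alone.

Measured compounds:
Compound 1, `Cc1ccc(CSc2cc(Cl)c(C)cc2S(=O)(=O)/N=C(\N)n2nc(C)cc2-c2ccccc2)cc1`: in an ADME assay on microsomes from liver (Homo sapiens) for metabolic stability, read by LC-MS, using NADPH, tested at 5 uM (on this read-out higher numbers stand for a longer-lived compound and lower numbers for a shorter-lived compound), compound 1 gives 0.176 h
Compound 2, `Cc1cc(S(=O)(=O)/N=C(\N)n2nccc2-c2ccccc2)c(SCc2ccccc2)cc1Cl`: in this assay compound 2 gives 0.0772 h
Compound 3, `Cc1cc(-c2ccccc2)n(/C(N)=N/S(=O)(=O)c2cc(C)c(Cl)cc2SCc2ccc(C(F)(F)F)cc2)n1`: in this assay compound 3 gives 0.241 h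

Compound 3 holds the highest of the three numbers in this assay. Compound 1 is nearest to it, and the step of a 1.4-fold higher number from compound 1 to compound 3 (0.14 log units; within the scatter) lies within the scatter, so the two cannot be told apart. Going by the values given here, compound 2 is furthest, its value lying beyond the scatter from compound 3, but compound 2 differs from compound 3 in more than one place, so its value alone sets no step.

Compound 4, `Cc1cc(-c2ccccc2)n(/C(N)=N/S(=O)(=O)c2cc(C)c(Cl)cc2SCc2ccccc2)n1`, arises from compound 3 by the change (hydrogen in place of trifluoromethyl on an aromatic carbon). Among the compounds with values here, the only step that bears on this position is a 1.4-fold higher number from compound 1 to compound 3 (0.14 log units; within the scatter), where one substituent on the same aromatic carbon was exchanged for another and the number barely moved. On that basis a step of similar size, a 1.5-fold lower number from compound 3 to compound 4 (0.18 log units; within the scatter), is expected in this assay, not beyond the scatter and if anything downward. Compound 4 is therefore estimated at 0.16 h, in the range 0.07 h to 0.32 h.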

Compound 4, half-life: 0.0938 h
Compound 4: the middle estimate sits 1.7-fold (0.23 log units) above what was measured, within the range that was stated.
By their numbers in this assay, from the lowest: compounds 2, 4, 1 and 3 (each within the scatter of the next, the first and the last beyond it).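

In this assay, the change on the aromatic carbon para to a large group now gives a step beyond the scatter (a 2.6-fold lower number from compound 3 to compound 4 (0.41 log units; beyond the scatter)), so trifluoromethyl and hydrogen can be told apart at this position. Methyl cannot be told apart from hydrogen there (a 1.9-fold lower number from compound 1 to compound 4 (0.27 log units; within the scatter)), and the earlier step showed the same for methyl and trifluoromethyl, so only the two ends of this short series separate. The methyl at the other place on the shared core also stays within the scatter (a 1.2-fold higher number from compound 2 to compound 4 (0.08 log units; within the scatter)), and no measurement shown here accounts for any of these steps.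

The compounds shown leave open how a fluorine, a methoxy, a nitrile or a carboxylic acid would behave at this position. They also leave open whether trifluoromethyl gives a similar step on the core of compound 2.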